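The source may hold more compounds than are shown below. What is called first, only, known or untested is meant among the compounds shown, and "the series" means these compounds.

Measured compounds:
compound 1 `Cn1c(-c2ccc(Cl)cc2)c(CCC(=O)N2CCN(Cc3ccccc3)CC2)c2cc(Cl)ccc21` — 0.3 nM
compound 2 `Cn1c(-c2ccc(Cl)cc2)c(CCC(=O)N2CCN(CC(C)(C)C)CC2)c2cc(Cl)ccc21` — 2 nM
compound 3 `CC(C)CCN1CCN(C(=O)CCc2c(-c3ccc(Cl)cc3)n(C)c3ccc(Cl)cc23)CC1` — 0.34 nM

Three compounds share one core and differ only in the group on a saturated chain carbon bound to an amine nitrogen in a ring. In an assay on CHO cells with Substance-P receptor (Homo sapiens) as the target (a lower number here means a stronger inhibitor, a higher number a weaker inhibitor), compound 3 gives 0.34 nM, the second highest of the three numbers; its nearest neighbour is compound 1, and that gap, a 1.1-fold higher number from compound 1 to compound 3 (0.05 log units; within the scatter), lies within the scatter. The furthest is compound 2: a 5.9-fold lower number from compound 2 to compound 3 (0.77 log units; beyond the scatter). The cost of the tert-butyl group also shows from compound 1, a 6.7-fold higher number from compound 1 to compound 2 (0.82 log units; beyond the scatter).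

Compound 4 `CN(C(=O)CN1CCN(C(=O)CCc2c(-c3ccc(Cl)cc3)n(C)c3ccc(Cl)cc23)CC1)c1ccccc1` has not yet been measured in this assay. The change from compound 3 is methyl(phenyl)carbamoyl in place of isobutyl on a saturated chain carbon bound to an amine nitrogen in a ring. Of the measured steps, the phenyl-to-isobutyl swap is the closest cue, since it shows that an aromatic ring at this carbon and a branched alkyl give numbers within the scatter of each other. For the measured compounds named here, no measured step carries an amide carbonyl into this position, so the comparison is loose. The expectation for compound 4 is a step of a 2.9-fold higher number from compound 3 to compound 4 (0.47 log units; beyond the scatter), small and likely within or near the scatter, with the tert-butyl case marking how much a poorly tolerated group could cost. The estimate for compound 4 in this assay is 1 nM, within 0.2 nM to 5 nM.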

Compound 4, half-maximal inhibitory concentration: 0.13 nM
Estimate against measurement, compound 4: 7.7-fold (0.89 log units) above, outside the stated range (below it).
By their numbers in this assay, from the lowest: compound 4; then compounds 1 and 3 (each within the scatter of the next); then compound 2.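

In this assay, for the compounds shown here, methyl(phenyl)carbamoyl at this saturated chain carbon bound to an amine nitrogen in a ring gives the lowest number so far, with a 2.6-fold lower number from compound 3 to compound 4 (0.42 log units; beyond the scatter) and a 2.3-fold lower number from compound 1 to compound 4 (0.36 log units; beyond the scatter), so an amide carbonyl is not merely accepted here and the position can go lower than the level shared by the phenyl and isobutyl groups. The span at this carbon also widens, with a 15-fold lower number from compound 2 to compound 4 (1.19 log units; beyond the scatter), and the group with 10 heavy atoms now stands at the low end while tert-butyl remains at the high end, so a large group at this position does not by itself carry a cost in these four compounds. No measured evidence on these compounds bears on the origin of this difference.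

Going by these compounds alone, only one carbamoyl group appears in the set, which leaves open whether the carbonyl, the phenyl ring or the methyl on the amide nitrogen accounts for the lower number. A dimethylcarbamoyl group, a phenylcarbamoyl group with the amide hydrogen in place of that methyl, or a carboxylic acid at this carbon would begin to separate these parts.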